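Acylation of the free amine on the octadecyl amide

A few compounds are considered here, and "the series" means these few. Any claim that something is new, unique, unknown or untested is made for them only; others in the source may bear on it.

Compound 2 `CCCCCCCCCCCCCCCCCCNC(=O)[C@@H](N)[C@@H](C)O` gives 27400 nM in a functional assay on MCF7 cells (Homo sapiens) for cytotoxicity, read by MTT assay, with a stated time of 48 h (a higher number here means a weaker inhibitor, a lower number a stronger inhibitor), the second highest of the three numbers to hand. Compound 1 `CCCCCCCCCCCCCCNC(=O)[C@@H](N)[C@@H](C)O` gives 10700 nM; the step is a 2.6-fold higher number from compound 1 to compound 2 (0.41 log units; beyond the scatter), butyl in place of hydrogen on a saturated chain carbon, ten or more bonds along the chain from an amide-type nitrogen. Compound 3 `CCCCCCCCCCCCNC(=O)[C@@H](NC(=O)c1ccco1)[C@@H](C)O`, which carries a dodecyl chain and a furan-2-carbonyl on the amine, gives 67500 nM; it differs from compound 2 in two places, so the two values are set side by side only.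

Compound 4 `C/C=C/C=C/C(=O)N[C@H](C(=O)NCCCCCCCCCCCCCCCCCC)[C@@H](C)O` differs from compound 2 by (penta-1,3-dien-1-yl)carbonyl in place of hydrogen on an amine nitrogen. Among the compounds with values here, no measured step acylates this amine alone. Within the data shown here, the only acylated compound, compound 3, carries the highest number, 67500 nM, while the free amines of compound 1 and compound 2 sit lower, which points to a higher number for compound 4. For compound 4 a modest rise is expected, a 1.6-fold higher number from compound 2 to compound 4 (0.22 log units; within the scatter), taken as a hint rather than a measured trend. Compound 4 is estimated at 45000 nM, within 15000 nM to 130000 nM.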

Compound 4, half-maximal inhibitory concentration: 79600 nM
Beside the measured number, compound 4's estimate is 1.8-fold (0.25 log units) below it, and the stated range covers the measured number.
By their numbers in this assay, from the lowest: compound 1; then compound 2; then compounds 3 and 4 (each within the scatter of the next).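

Acylation of this amine now has a step of its own in this assay: (penta-1,3-dien-1-yl)carbonyl in place of hydrogen on the amine nitrogen gives a 2.9-fold higher number from compound 2 to compound 4 (0.46 log units; beyond the scatter) with the octadecyl chain held fixed. Compound 3 could not show this, since it differs from compound 2 in two places, so the free amine carrying the lower number is now a measured result for this one pair, not a side-by-side impression. Nothing on hand accounts for the change in number at this position.

As far as these compounds go, whether an acetyl or a saturated hexanoyl on the same amine nitrogen would give a step of similar size stays open. Also open, from the compounds shown here alone, is whether acylation of the tetradecyl amide of compound 1 would move its number the same way.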